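The compounds below may be only part of what the source reports. "The series", "measured", "known", "first", "only" and "open" are said of these compounds alone.

Measured compounds:
Compound 1 `Cc1ccc(OCC(=O)N(Cc2cccs2)c2ccnn2C)cc1`, 422 nM
Compound 2 `CCN(Cc1cccs1)C(=O)COc1ccc(C(C)C)cc1`, 397 nM
Compound 3 `COc1ccc(OCC(=O)N(Cc2cccs2)c2ccn[nH]2)cc1`, 3.7 nM

All three were tested in an assay on HEK293 cells for agonist activity at transient receptor potential cation channel subfamily M member 8 (Homo sapiens), read by fluorescence and calcium flux, with a stated time of 15 min; a higher number here means that more compound is needed for the effect, a lower number that less compound is needed. Compound 1 has the highest number of the three, 422 nM. Compound 2, with 397 nM, sits within the usual scatter of compound 1, so the two cannot be told apart on these measurements. Compound 3, with 3.7 nM, lies far below both, well beyond the scatter, but it differs from compound 1 in more than one place, so no single change can be credited for that gap.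

Compound 4 `Cc1ccc(OCC(=O)N(Cc2cccs2)c2nccn2C)cc1` has not yet been measured. It is built from the same atoms as compound 1, joined differently: 1-methyl-1H-imidazol-2-yl in place of 1-methyl-1H-pyrazol-5-yl on an amide-type nitrogen. Going by the values given here, no pair of measured compounds shows this change by itself, so there is no measured step to lean on. Swapping one five-membered aromatic ring with 2 hetero atoms for another of the same size and count is expected to leave the number near where compound 1 stands, with no step beyond the scatter in either direction. The resulting step is expected to be a 1.2-fold higher number from compound 1 to compound 4 (0.07 log units; within the scatter). Compound 4 is expected to give 500 nM in this assay, most likely between 120 nM and 2000 nM.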

Compound 4, half-maximal effective concentration: 1790 nM
Beside the measured number, compound 4's estimate is 3.6-fold (0.55 log units) below it, and the stated range covers the measured number.
By their numbers in this assay, from the lowest: compound 3; then compounds 2 and 1 (each within the scatter of the next); then compound 4.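

In this assay, putting 1-methyl-1H-imidazol-2-yl in place of 1-methyl-1H-pyrazol-5-yl on an amide-type nitrogen gives a 4.2-fold higher number from compound 1 to compound 4 (0.63 log units; beyond the scatter). The two groups have identical counts of carbon and nitrogen atoms, hydrogen-bond donors and acceptors, and neither carries a net charge, so at this position the number responds to how the atoms of the ring are joined, even when the counts stay the same. Nothing measured here explains why this rearrangement moves the number.

Still open, from the compounds shown here alone, is what other rings on this same nitrogen would do: a pyridine ring or a thiazole ring, for example, might stay close to compound 1, go further in the direction of compound 4, or move the other way. Going by these compounds, the swap is also seen in this single pair only, so it remains unknown whether it would give a step of similar size with a different group in place of the methyl on the phenoxy ring of compound 1.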